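A Shorter Hydroxyalkyl Chain: Estimating Compound 4

This account rests on a few compounds, and the source may have more. Where it says the series, first, only, none or still open, it means among the compounds named here.

Three compounds that share one core have been measured in an ADME assay on PANC-1 cells (Homo sapiens) for cytotoxicity, read by sulforhodamine B assay, with a stated time of 48 h, tested at 10 uM; a higher number here means more inhibition at the concentration tested (going by the name of the read-out), a lower number less inhibition:

Compound 1 `COc1nc2ccc(Br)cc2cc1C(c1ccccc1)n1cc(-c2ccc(Br)cc2)nn1` gives 10.4%.
Compound 2 `COc1nc2ccc(Br)cc2cc1C(c1ccccc1)n1cc(CCCO)nn1` gives 25.5%.
Compound 3 `CCCc1cn(C(c2ccccc2)c2cc3cc(Br)ccc3nc2OC)nn1` gives 11.3%.

Compound 3 stands second highest of the three. Its nearest neighbour is compound 1, and that gap is within the usual scatter, so the two cannot be told apart. Compound 2 stands furthest from compound 3, and that gap is beyond the scatter.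

Compound 4 `COc1nc2ccc(Br)cc2cc1C(c1ccccc1)n1cc(CCO)nn1` has not yet been measured. It differs from compound 3 in one place: hydroxy in place of methyl on a saturated chain carbon, two bonds along the chain from an aromatic carbon. Put another way, the propyl of compound 3 becomes a 2-hydroxyethyl.

For the measured compounds named here, two measured steps bear on this. The closest is a number 14.2 percentage points lower from compound 2 to compound 3 (beyond the scatter), where the hydroxy left the chain and the number fell modestly. The other is a number 15.1 percentage points higher from compound 1 to compound 2 (beyond the scatter), where the compound carrying the hydroxypropyl again gave the higher number. Restoring a hydroxy to the chain, here on a shorter chain, is therefore expected to raise the number by a modest amount, although no measured pair shows this shorter chain itself. For compound 4 the step is expected to be a number 10.7 percentage points higher from compound 3 to compound 4 (beyond the scatter). Compound 4 is thus estimated at 22%, with a likely range from 10% to 34%.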

Compound 4, a percentage reported as inhibition, at one concentration (the size of the read-out at that concentration, not a potency): 19.8%
For compound 4 the middle estimate is 2.2 percentage points above the measured one; measured number inside the range.
By their numbers in this assay, from the lowest: compounds 1, 3, 4 and 2 (each within the scatter of the next, the first and the last beyond it).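

In this assay, hydroxy in place of methyl on this chain gives a number 8.5 percentage points higher from compound 3 to compound 4 (within the scatter), so this change does not separate the 2-hydroxyethyl from the propyl, whereas the earlier step between 3-hydroxypropyl and propyl was beyond the scatter. The 2-hydroxyethyl also cannot be told apart from the 3-hydroxypropyl, with a number 5.7 percentage points lower from compound 2 to compound 4 (within the scatter), and putting it in place of 4-bromophenyl gives a number 9.4 percentage points higher from compound 1 to compound 4 (within the scatter), a smaller result than the earlier step from 4-bromophenyl to 3-hydroxypropyl, which stood beyond the scatter. No measurement available here explains any of these numbers.

With compound 4 within the scatter of all three other compounds, these results leave open whether the hydroxy makes a real difference on the 2-hydroxyethyl chain, and a repeat measurement would be needed to settle so small a step. A longer chain such as 4-hydroxybutyl, or an amine or a carboxylic acid in place of the hydroxy, would test whether this position can give a number clearly apart from those of the propyl and 4-bromophenyl compounds.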